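A chloro step from compound 1 to compound 3

A few compounds are considered here, and "the series" means these few. Any claim that something is new, unique, unknown or untested is made for them only; others in the source may bear on it.

Measured in a functional assay on HL60/MX2 cells (Homo sapiens) for antiproliferative activity, read by MTT assay, with a stated time of 48 h; on this read-out lower numbers stand for stronger inhibition and higher numbers for weaker inhibition:
Compound 1 `CCN(CC)CCCn1c(N)c(-c2nc3ccccc3[nH]2)c2nc(C#N)c(C#N)nc21` (1820 nM)
Compound 2 `N#Cc1nc2c(-c3nc4ccccc4[nH]3)c(N)n(CCCO)c2nc1C#N` (> 50000 nM, a limit)

Among the measured compounds shown here, compound 1 (1820 nM) holds the only number in this assay so far. Compound 2 gave only a limit (> 50000 nM).

Compound 3 `CCN(CC)CCCn1c(N)c(-c2nc3cc(Cl)ccc3[nH]2)c2nc(C#N)c(C#N)nc21` differs from compound 1 in one place: chloro in place of hydrogen on an aromatic carbon, which turns 1H-benzimidazol-2-yl into 5-chloro-1H-benzimidazol-2-yl. For the measured compounds named here, the only measured step (an at least 27-fold higher number from compound 1 to compound 2 (1.43 log units; beyond the scatter)) is large, but it sits on a saturated chain carbon and leaves this aromatic carbon untouched, so it gives no size for the new change. In this assay a step within the scatter is therefore expected, with no firm direction. The estimated step is small (a 1.2-fold lower number from compound 1 to compound 3 (0.08 log units; within the scatter)). For compound 3 the expected value is 1500 nM (estimated range 450 nM to 5500 nM).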

Compound 3, half-maximal inhibitory concentration: 2460 nM
Compound 3: middle estimate off by 1.6-fold (0.21 log units), on the low side; low and high end bracket the measured number.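

In this assay, among the compounds shown here, the step to 5-chloro-1H-benzimidazol-2-yl gives the first reading at this aromatic carbon: a 1.4-fold higher number from compound 1 to compound 3 (0.13 log units; within the scatter). Chloro in place of hydrogen at this carbon therefore produces no difference that this assay can resolve, and compound 3 and compound 1 stand level within the scatter, so this single change gives no sign of either gain or loss. No measurement shown bears on why this substitution behaves as it does.

The compounds shown leave open whether bromo, methoxy, an amine or a carboxylic acid at this same carbon would also stay within the scatter of compound 1. They also leave open how chloro would read on the other aromatic carbons of this ring, or when combined with the hydroxy chain of compound 2.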